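The source may hold more compounds than are shown below. What is called first, only, known or untested is meant among the compounds shown, and "the series" means these compounds.

Measured so far:
- Compound 1 `Cc1ccccc1NNC(=O)c1ccc(NS(=O)(=O)c2cnc(O)nc2O)cc1`: 14500 nM
- Compound 2 `O=C(NNc1ccccc1F)c1ccc(NS(=O)(=O)c2cnc(O)nc2O)cc1`: 11700 nM

Among the compounds with values here, only two compounds have been measured in a functional assay on A549 cells (Homo sapiens) for antiproliferative activity, read by MTT assay, with a stated time of 24 h (on this read-out higher numbers stand for weaker inhibition and lower numbers for stronger inhibition), and they cannot be told apart. Compound 2, at 11700 nM, sits level with compound 1 once ordinary scatter is allowed for.

The next compound is compound 3 `O=C(NNc1ccc(F)cc1)c1ccc(NS(=O)(=O)c2cnc(O)nc2O)cc1`, which has the same atoms as compound 2, joined differently: 4-fluorophenyl in place of 2-fluorophenyl on an amine nitrogen. In other words, 4-fluorophenyl stands in place of 2-fluorophenyl on an amine nitrogen.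

Within the data shown here, only one measured step bears on this, and only indirectly: a 1.2-fold lower number from compound 1 to compound 2 (0.09 log units; within the scatter). Among the measured compounds shown here, that step exchanged one group for another, and no measured pair tests the change made here. With so little evidence, and with that one step so small, no shift beyond the scatter is expected, in either direction. The expected step is a 1.0-fold higher number from compound 2 to compound 3 (0.01 log units; within the scatter). Compound 3 is estimated at 12000 nM, with an expected range of 6000 nM to 24000 nM.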

Compound 3, half-maximal inhibitory concentration: > 20000 nM
Compound 3 was reported as a limit (the forecaster's own chance of this, stated with the estimate: 5%); at least 1.6-fold (0.22 log units) between middle value and limit.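

Within the data shown here, exchanging 2-fluorophenyl for 4-fluorophenyl on an amine nitrogen keeps the same atoms but joins them differently, so this is the first look at where the fluoro sits rather than which group is present. In this assay compound 3 gives > 20000 nM, which is a limit of the assay and not a number: the limit of > 20000 nM in this assay, at which 1 of the 3 values shown sits. The steps read an at least 1.7-fold higher number from compound 2 to compound 3 (0.23 log units; that floor lies within the scatter) and an at least 1.3-fold higher number from compound 1 to compound 3 (0.13 log units; that floor lies within the scatter), so neither floor shows a change beyond the scatter, although the true gaps may be larger.

On these data alone, how far compound 3 really lies from the other two stays open. Also open, as far as these compounds go, is how a plain phenyl or a 4-methylphenyl on the same amine nitrogen would read out, which would show whether 4-fluorophenyl behaves differently from other groups there.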